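Dropping the chloro: from compound 2 to compound 4

The compounds below may be only part of what the source reports. "The series", "measured", "known", "first", "only" and "open" are said of these compounds alone.

Measured compounds:
compound 1, `Clc1ccc2[nH]c(SCc3ccccc3/C=C\c3ccccc3)nc2c1`, 49%
compound 2, `Clc1ccc2[nH]c(SCc3ccccc3CCc3ccccc3)nc2c1`, 47%
compound 3, `[O-][S+](Cc1ccccc1)c1ccccc1CSc1nc2cc(Cl)ccc2[nH]1`, 11%

All three numbers come from an assay on isolated protein for inhibition of Indoleamine 2,3-dioxygenase 1 (Homo sapiens), with a stated time of 60 min, tested at 10 uM; on this read-out lower numbers stand for less inhibition and higher numbers for more inhibition at the one concentration tested (going by the name of the read-out). Compound 2 stands second highest of the three. Its nearest neighbour is compound 1, with a number 2 percentage points lower from compound 1 to compound 2 (within the scatter). Its furthest is compound 3, with a number 36 percentage points lower from compound 2 to compound 3 (beyond the scatter); the two larger steps, a number 38 percentage points lower from compound 1 to compound 3 (beyond the scatter) and the one just named, both come from exchanging the group on the aromatic carbon away from the shared core.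

Compound 4, `c1ccc(CCc2ccccc2CSc2nc3ccccc3[nH]2)cc1`, differs from compound 2 only in this way: hydrogen in place of chloro on an aromatic carbon. None of the measured steps touches the chloro; every step shown alters the other side of the molecule. So there is no direct guide, and the chloro itself has no measured counterpart here. Since the steps that left the core untouched and changed a saturated link for an unsaturated one stayed within the scatter, while only a change of atom type brought a large drop, a modest change is expected for compound 4, with a number 7 percentage points lower from compound 2 to compound 4 (within the scatter).

Compound 4 is therefore estimated at 40%, within a range from 20% to 58%.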

Compound 4, a percentage reported as inhibition, at one concentration (the size of the read-out at that concentration, not a potency): 43%
Beside the measured number, compound 4's estimate is 3 percentage points below it; the range from low to high includes it.
By their numbers in this assay, from the lowest: compound 3; then compounds 4, 2 and 1 (each within the scatter of the next).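

In this assay, within the data shown here, hydrogen in place of chloro on the aromatic carbon of the shared core, meta to a fused ring and para to a fused ring, gives a number 4 percentage points lower from compound 2 to compound 4 (within the scatter), which is the first step here that touches this side of the molecule. For this pair the chloro is therefore not needed to keep the inhibition seen at the one concentration tested, and the size of this step stands in contrast to the change on the other side of the molecule, a number 36 percentage points lower from compound 2 to compound 3 (beyond the scatter), so among these compounds only that exchanged group moves the number beyond the scatter. No measurement at hand bears on why the number stays level with the loss of the chloro.

On these data alone, whether a fluoro, a methoxy, an amine or a carboxylic acid on this same aromatic carbon would also leave the number within the scatter remains open, since hydrogen and chloro are the only two substituents compared here. As far as these compounds go, it is also open whether the same exchange would behave alike in compound 1 or compound 3, whose other side differs, because this single pair rests on the phenethyl series alone.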